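The compounds below may be only part of what the source reports. "The series", "measured", "known", "first", "only" and "open" are said of these compounds alone.

Compound 1 `CCCCCC(=O)c1c(O)c(Cl)c(OC)c(Cl)c1O` gives 4600 nM in a functional assay on the whole organism (S2 cells, strain S2) for inhibition, with Drosophila as the target, read by a luciferase reporter, with stated times of 1.5 h and 8 h; a lower number here means a stronger inhibitor, a higher number a weaker inhibitor. Compound 2 `CCCCCC(=O)c1c(O)c(Cl)c(C)c(Cl)c1O` gives 3800 nM in this assay.

Among these two numbers compound 1 stands highest, with compound 2 nearest, and the only measured step is a 1.2-fold lower number from compound 1 to compound 2 (0.08 log units; within the scatter), which changes a different position and so does not bear on the change to compound 3 `CCCCCC(=O)c1c(O)cc(OC)c(Cl)c1O`. That change is hydrogen in place of chloro on an aromatic carbon. Going by the values given here, with no step that speaks to removing a chloro group, nothing beyond the scatter can be argued for in either direction. Compound 3 is therefore expected at about 6000 nM, within 2000 nM to 20000 nM, a step estimated as a 1.3-fold higher number from compound 1 to compound 3 (0.12 log units; within the scatter).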

Compound 3, half-maximal inhibitory concentration: 4600 nM
Beside the measured number, compound 3's estimate is 1.3-fold (0.12 log units) above it, within the range that was stated.
By their numbers in this assay, from the lowest: compounds 2, 1 and 3 (each within the scatter of the next).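

In this assay, hydrogen in place of the chloro group that sits ortho to a methoxy group gives no change at the digits printed from compound 1 to compound 3 (within the scatter). This position of the core of compound 1 therefore tolerates the loss of its chloro group, and compound 3 keeps the inhibition with only the remaining chloro group on the ring. Nothing measured here says why this is so.

As far as these compounds go, whether a bromo group, an amine or a carboxylic acid at this position would also leave the number within the scatter remains open. So does the outcome of replacing the remaining chloro group with hydrogen as well.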